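This account rests on a few compounds, and the source may have more. Where it says the series, first, only, none or still open, it means among the compounds named here.

Measured so far in an ADME assay on microsomes from liver (Mus musculus) for metabolic stability, read by LC-MS, using NADPH, with a stated time of 30 min, tested at 1.5 uM; a higher number here means that more of the compound is left, a lower number that less of the compound is left:

Compound 1, `CCn1cc(Nc2nc(N)nc(-c3cccc(-n4ccc5cc(C6CC6)cc(F)c5c4=O)c3CO)n2)cc1C#N`: 32%
Compound 2, `Nc1nc(Nc2cnn(C3CC3)c2)nc(-c2cccc(-n3ccc4cc(C5CC5)cc(F)c4c3=O)c2CO)n1`: 16%

Compound 2 stands lowest of the two numbers in this assay; its nearest neighbour is compound 1, whose value is higher by an amount beyond the scatter, as the step of a number 16 percentage points lower from compound 1 to compound 2 (beyond the scatter) shows.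

Compound 3 is `Cn1cc(Nc2nc(N)nc(-c3cccc(-n4ccc5cc(C6CC6)cc(F)c5c4=O)c3CO)n2)cc1C#N` and has not been measured. Its difference from compound 2 is 5-cyano-1-methyl-1H-pyrrol-3-yl in place of 1-cyclopropyl-1H-pyrazol-4-yl on a nitrogen on an aromatic ring. Within the data shown here, the only measured step that bears on this is a number 16 percentage points lower from compound 1 to compound 2 (beyond the scatter), which runs the other way: from the cyanopyrrolyl of compound 1 to the cyclopropylpyrazolyl of compound 2. Among the measured compounds shown here, compound 3 carries the cyanopyrrolyl again, with a methyl in place of the ethyl of compound 1; no step for that methyl-to-ethyl change is known. The step of a number 16 percentage points lower from compound 1 to compound 2 (beyond the scatter) is therefore taken as the template and expected to reverse, placing compound 3 near compound 1. The expected step is a number 14 percentage points higher from compound 2 to compound 3 (beyond the scatter), upward and beyond the scatter. Compound 3 is estimated at 30%, in a range from 18% to 44%.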

Compound 3, percent of the compound remaining: 46%
Compound 3: the middle estimate sits 16 percentage points below what was measured, outside the stated range (above it).
By their numbers in this assay, from the lowest: compound 2; then compound 1; then compound 3.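

The group on the ring nitrogen of the cyanopyrrolyl is not a silent part of this position: methyl in place of ethyl alone gives a number 14 percentage points higher from compound 1 to compound 3 (beyond the scatter) in this assay. The full exchange of 1-cyclopropyl-1H-pyrazol-4-yl for 5-cyano-1-methyl-1H-pyrrol-3-yl on the aromatic amine nitrogen gives a number 30 percentage points higher from compound 2 to compound 3 (beyond the scatter), so the outcome at this position depends on the small alkyl group as well as on the ring that carries it. Nothing measured here accounts for either step.

The shown compounds do not separate the contributions of the ring, the nitrile and the alkyl group, which a 1-methyl-1H-pyrazol-4-yl group could help to resolve. On these data alone, whether the trend across ethyl and methyl extends to a hydrogen on that ring nitrogen, or reverses with a propyl chain, also remains open.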